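A few compounds are considered here, and "the series" means these few. Any claim that something is new, unique, unknown or untested is made for them only; others in the source may bear on it.

Measured so far in a functional assay on HT-1080 cells (Homo sapiens) for cytotoxicity, read by MTT assay, with a stated time of 72 h; on this read-out lower numbers stand for stronger inhibition and higher numbers for weaker inhibition:

compound 1 `Cc1ccc2cc3c(nc2c1)-c1nc2ccccc2n1C3`, 8700 nM
compound 2 `Cc1ccc2nc3c(cc2c1)Cn1c-3nc2ccccc21`, 9300 nM
compound 3 `COc1ccc2cc3c(nc2c1)-c1nc2ccccc2n1C3`, 95000 nM

Compound 1 and compound 2 share the same atoms joined differently; the difference between the two cores is not broken down here. Their values in this assay lie within the scatter of each other, so no order between them can be drawn. Compound 3 carries the change

methoxy in place of methyl on an aromatic carbon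

and this change is tied to an 11-fold higher number from compound 1 to compound 3 (1.04 log units; beyond the scatter). Compound 3 thus stands apart from compound 1 and compound 2, both of which sit well under it.

Compound 4 `COc1ccc2nc3c(cc2c1)Cn1c-3nc2ccccc21` is not yet measured. It stands to compound 2 as compound 3 stands to compound 1, namely through

methoxy in place of methyl on an aromatic carbon

The two place descriptions are the same word for word, so this is the same change made on the core of compound 2 rather than on the core of compound 1. Among the measured compounds shown here, only one measured example of the change exists, so the expectation for compound 4 rests on it alone, together with the observation that compound 1 and compound 2 give values within the scatter of each other in this assay. From compound 2 the step is expected to be an 11-fold higher number from compound 2 to compound 4 (1.03 log units; beyond the scatter), taken to be of the same size as the measured step in the earlier pair because of an 11-fold higher number from compound 1 to compound 3 (1.04 log units; beyond the scatter). As far as these compounds go, on that basis compound 4 is estimated at 100000 nM in this assay, with a range from 40000 nM to 250000 nM, the width reflecting that the transfer from one core to the other is untested.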

Compound 4, half-maximal inhibitory concentration: 52300 nM
Compound 4: the middle estimate sits 1.9-fold (0.28 log units) above what was measured; measured number inside the range.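

In this assay, methoxy in place of methyl on an aromatic carbon again moves the read-out towards weaker inhibition on the second core, with a 5.6-fold higher number from compound 2 to compound 4 (0.75 log units; beyond the scatter). The change therefore carries across the two cores in the same direction, and the two steps cannot be told apart in size: the same change on two cores in this assay, an 11-fold higher number (1.04 log units; beyond the scatter) from compound 1 to compound 3 and a 5.6-fold higher number (0.75 log units; beyond the scatter) from compound 2 to compound 4, 1.9-fold (0.29 log units) apart, within the scatter of two such steps
Among the compounds shown here, this agreement rests on only two matched pairs, so it does not show that the step would hold on any core beyond these two, and it gives no reason why methoxy reads weaker than methyl in this cell assay.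

The compounds shown leave open how other groups on this same aromatic carbon would read, for example a plain hydrogen, a fluorine, a hydroxyl, an amine, a carboxylic acid or a longer chain such as ethoxy, and so whether methyl itself adds anything or methoxy alone takes away. Also open, as far as these compounds go, is whether methoxy in place of methyl would give a similar step on a different aromatic carbon of either core.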